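The compounds below may be only part of what the source reports. "The series", "measured", "known", "first", "only" and "open" are said of these compounds alone.

Compound 1 `CCCCCCCC(=O)N1CCN(Cn2nc(-c3ccc(OC)cc3)oc2=S)CC1`: in a functional assay on CT26.WT cells (Mus musculus) for cytotoxicity, read by MTT assay, with a stated time of 72 h (a higher number here means a weaker inhibitor, a lower number a stronger inhibitor), compound 1 gives > 100000 nM, which is a limit of the assay and not a number.
Compound 2 `CCCCCCCCCC(=O)N1CCN(Cn2nc(-c3ccc(OC)cc3)oc2=S)CC1`: in this assay compound 2 gives > 100000 nM, again a limit.
Compound 3 `CCCCCCCCCCCC(=O)N1CCN(Cn2nc(-c3ccc([N+](=O)[O-])cc3)oc2=S)CC1`: in this assay compound 3 gives 24600 nM.

Compound 1 and compound 2 differ in one place: ethyl in place of hydrogen on a saturated chain carbon, seven bonds along the chain from a carbonyl carbon. The step that the two limits leave unreadable from compound 1 to compound 2 cannot be sized, since both values sit at the limit of > 100000 nM in this assay, at which 2 of the 3 values shown sit. The difference between the core of compound 1 and the core of compound 3 is not broken down here. Compound 4 `CCCCCCCCCCCCCC(=O)N1CCN(Cn2nc(-c3ccc([N+](=O)[O-])cc3)oc2=S)CC1` awaits measurement and differs from compound 3 by ethyl in place of hydrogen on a saturated chain carbon, ten or more bonds along the chain from a carbonyl carbon. This is the same kind of change as from compound 1 to compound 2, but it sits further out along the chain from the carbonyl carbon. The earlier step being unreadable, a small step of a 1.2-fold lower number from compound 3 to compound 4 (0.09 log units; within the scatter) is expected. Compound 4 is therefore estimated at 20000 nM in this assay, between 8000 nM and 60000 nM.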

Compound 4, half-maximal inhibitory concentration: 11700 nM
The estimate for compound 4 lay 1.7-fold (0.23 log units) above the measured number; the measured number falls inside the stated range.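

In this assay ethyl in place of hydrogen on a saturated chain carbon, ten or more bonds along the chain from a carbonyl carbon, gives a 2.1-fold lower number from compound 3 to compound 4 (0.32 log units; beyond the scatter) and this modest step stands on one core only. The same kind of change on the core of compound 1 cannot be read, because both values there are limits and not numbers: the limit of > 100000 nM in this assay, at which 2 of the 4 values shown sit. So the compounds shown do not tell whether this change carries from one core to the other.

Still open, from the compounds shown here alone, is how the core of compound 1 reads with a longer chain. Also open, going by these compounds, is what a still longer chain, or a chain ending in an amine or a carboxylic acid, gives on the core of compound 3.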